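One five-membered ring for another: estimating compound 4

The source may hold more compounds than are shown below. What is called first, only, known or untested is meant among the compounds shown, and "the series" means these compounds.

Measured in a functional assay on A2780 cells (Homo sapiens) for inhibition; on this read-out lower numbers stand for stronger inhibition and higher numbers for weaker inhibition:
compound 1 `CC(C(=O)Nc1cc(C2CC2)[nH]n1)c1ccc(N2CCC(C(N)=O)C2=O)cc1` gives 5710 nM
compound 2 `CC(C(=O)Nc1cc(C2CC2)[nH]n1)c1ccc(-n2cnnc2O)cc1` gives 8390 nM
compound 3 `C[C@H](C(=O)Nc1cc(C2CC2)[nH]n1)c1ccc(N2CCCC2)cc1` gives 220 nM

Compound 2 has the highest number of the three; compound 1 is nearest, within the scatter, while compound 3 lies far below it, beyond the scatter. Compound 4 `CC(C(=O)Nc1cc(C2CC2)[nH]n1)c1ccc(N2CCNC2=O)cc1` differs from compound 2 in one place: a group of 6 heavy atoms (3 carbon, 2 nitrogen, 1 oxygen; one five-membered non-aromatic ring with 2 hetero atoms) in place of a group of 6 heavy atoms (2 carbon, 3 nitrogen, 1 oxygen; one five-membered aromatic ring with 3 hetero atoms), on an aromatic carbon. Going by the values given here, the only measured step that bears on this change is a 1.5-fold higher number from compound 1 to compound 2 (0.17 log units; within the scatter), where exchanging a non-aromatic five-membered ring for the aromatic one of compound 2 did not move the number beyond the scatter. The group entering compound 4 is again a non-aromatic five-membered ring, like that of compound 1. For compound 4 a modest move toward lower numbers in this assay is expected, a 2.4-fold lower number from compound 2 to compound 4 (0.38 log units; beyond the scatter), not clearly beyond the scatter. Compound 4 is therefore estimated at 3500 nM, with a range of 900 nM to 13000 nM.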

Compound 4, half-maximal inhibitory concentration: 2250 nM
For compound 4 the middle estimate is 1.6-fold (0.19 log units) above the measured one; the range from low to high includes it.
By their numbers in this assay, from the lowest: compound 3; then compound 4; then compounds 1 and 2 (each within the scatter of the next).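

On the aromatic carbon para to a large group, this ring exchange moves the number beyond the scatter (a 3.7-fold lower number from compound 2 to compound 4 (0.57 log units; beyond the scatter)), unlike the earlier step between compound 1 and compound 2. The 2-oxoimidazolidin-1-yl group also separates from the larger non-aromatic ring of compound 1 (a 2.5-fold lower number from compound 1 to compound 4 (0.40 log units; beyond the scatter)), so the non-aromatic five-membered rings at this place are not interchangeable. No measurement shown accounts for either step. As far as these compounds go, whether a piperazine ring or an open-chain urea in the same place would give a lower or higher number than compound 4 remains open.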